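This account rests on a few compounds, and the source may have more. Where it says the series, first, only, none or still open, it means among the compounds named here.

Compound 3, `c1coc(-c2ncnc3[nH]cc(Sc4cccs4)c23)c1`, is the compound from which the next step is taken. In a functional assay on HCT-116 cells (Homo sapiens), read by MTT assay, with a stated time of 3 days (a higher number here means a weaker inhibitor, a lower number a stronger inhibitor), compound 3 gives 19500 nM. Compound 1, `COc1ncnc2[nH]cc(Sc3cccs3)c12`, reaches only the limit of the limit of > 50000 nM in this assay, at which 1 of the 3 values shown sits, in this assay; compound 1 gives > 50000 nM, which is a limit and not a number. Compound 2, `CN(C)c1ncnc2[nH]cc(Sc3cccs3)c12`, gives 27500 nM in this assay. The steps that lead to compound 3 are an at least 2.5-fold lower number from compound 1 to compound 3 (0.40 log units; beyond the scatter) and a 1.4-fold lower number from compound 2 to compound 3 (0.15 log units; within the scatter); the step of an at least 1.8-fold lower number from compound 1 to compound 2 (0.25 log units; that floor lies within the scatter) runs between the other two compounds. Compound 3 therefore holds the lowest of the two numbers shown, with compound 2 nearest to it and within the scatter, so no order between those two can be stated.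

Compound 4, `c1csc(Sc2c[nH]c3ncnc(-c4cccs4)c23)c1`, differs from compound 3 by thiophen-2-yl in place of furan-2-yl on an aromatic carbon. Among the compounds with values here, no measured step exchanges one five-membered aromatic ring with one hetero atom for another; the measured steps only put a furan-2-yl group in place of methoxy or dimethylamino, and the largest of them, from compound 1, was modest. The expected step of a 1.3-fold lower number from compound 3 to compound 4 (0.11 log units; within the scatter) is thus small, within the scatter, in either direction. Compound 4 is estimated at 15000 nM in this assay, with a range from 5000 nM to 45000 nM.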

Compound 4, half-maximal inhibitory concentration: 5060 nM
Compound 4: middle estimate off by 3.0-fold (0.47 log units), on the high side; low and high end bracket the measured number.
By their numbers in this assay, from the lowest: compound 4; then compounds 3 and 2 (each within the scatter of the next). At a limit, above all of these: compound 1.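

Within the data shown here, this is the first measured exchange of one five-membered aromatic ring with 1 hetero atom for another at this position, and putting sulfur in place of oxygen, with the heavy-atom count unchanged, gives a 3.9-fold lower number from compound 3 to compound 4 (0.59 log units; beyond the scatter) in this assay. Furan-2-yl and dimethylamino could not be told apart here, whereas thiophen-2-yl separates from dimethylamino, with a 5.4-fold lower number from compound 2 to compound 4 (0.74 log units; beyond the scatter), so the identity of the ring's hetero atom matters more at this position than the earlier compounds could show, and compound 4 holds the lowest number of the set. For compound 1, which is held at a limit and not a number, only a floor can be given, an at least 9.8-fold lower number from compound 1 to compound 4 (0.99 log units; beyond the scatter), and it rests on this: the limit of > 50000 nM in this assay, at which 1 of the 4 values shown sits.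

The compounds shown do not tell why sulfur in this ring lowers the number, and this single exchange does not show whether the effect would hold on another core. Also open, going by these compounds, is whether thiophen-3-yl, a thiazole, or a six-membered ring such as phenyl or pyridine at this position would lower the number further.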